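Hydroxy on the Piperidine Ring: Predicting Compound 3

The compounds below may be only part of what the source reports. "The series", "measured", "known", "first", "only" and "open" are said of these compounds alone.

Measured compounds:
- compound 1 `O=C(CN1CCNCC1)N1N=C(c2ccc(F)cc2)CC1c1cc(Cl)ccc1O`: 2400 nM
- compound 2 `CC1=NN(C(=O)CN2CCCCC2)C(c2cc(Br)cc(Br)c2O)C1`: 7800 nM

Of the compounds shown here, two have been measured in an assay on isolated protein for inhibition of Amine oxidase [flavin-containing] A (Homo sapiens), read by fluorescence, with stated times of 15 min and 20 min; a higher number here means a weaker inhibitor, a lower number a stronger inhibitor. Compound 1 gives 2400 nM in this assay, and compound 2 gives 7800 nM. Of these two numbers, compound 2 has the higher one, meaning it is the weaker inhibitor, and its gap to compound 1 lies beyond the usual scatter. Going by the values given here, the two compounds differ in several places at once, so their values show only that compound 2 sits above compound 1, and nothing about which part of the structure accounts for it.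

Compound 3 `CC1=NN(C(=O)CN2CCC(O)CC2)C(c2cc(Br)cc(Br)c2O)C1` is not yet measured. It is built from compound 2 by one change: hydroxy in place of hydrogen on a saturated ring carbon. Among the compounds with values here, no step between measured compounds of this kind is available, so there is nothing to lean on except the value of compound 2 itself. A change of this size is expected to move the number little; the step of a 1.1-fold lower number from compound 2 to compound 3 (0.05 log units; within the scatter) is estimated to stay within the scatter, in no particular direction. Compound 3 is therefore expected to give about 7000 nM, with a range from 2500 nM to 20000 nM.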

Compound 3, half-maximal inhibitory concentration: 12400 nM
Compound 3: middle estimate off by 1.8-fold (0.25 log units), on the low side; the measured number falls inside the stated range.
By their numbers in this assay, from the lowest: compound 1; then compounds 2 and 3 (each within the scatter of the next).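

In this assay, going by these compounds alone, this is the first comparison of two compounds that differ in one place only: going from piperidin-1-yl to 4-hydroxypiperidin-1-yl gives a 1.6-fold higher number from compound 2 to compound 3 (0.20 log units; within the scatter) and so isolates this single change. The ring carbon three ring bonds from the ring nitrogen can therefore carry a hydroxy, with its one hydrogen-bond donor and one hydrogen-bond acceptor, without any difference that can be told apart from the ordinary spread of repeated measurements. The data offer no measured explanation for this outcome, so it stands as an observation about this one pair of compounds.

The compounds shown leave open whether an amine, a carboxylic acid or a methoxy group on this same ring carbon would produce a step beyond the scatter, and whether a hydroxy on a different carbon of the ring would read the same way. They also leave open whether the same hydroxy change would give a similar result on the core of compound 1, since a single pair cannot show how general it is.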